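Moving the chlorine on the aryl arm of compound 3

The compounds below may be only part of what the source reports. "The series", "measured", "known", "first", "only" and "open" are said of these compounds alone.

Three compounds of the series have numbers in an assay on Sf9 cells for inhibition of protein deacetylase HDAC6 (Homo sapiens), read by fluorescence, with a stated time of 40 min, tested at 100 nM; a higher number here means more inhibition at the concentration tested (going by the name of the read-out), a lower number less inhibition. Compound 1 `Cc1ccc(-c2nc(CNc3ccc(C(=O)NO)cc3)n(-c3ccccc3)n2)cc1` gives 62.2%. Compound 2 `Cc1cccc(-n2nc(-c3ccccc3)nc2CNc2ccc(C(=O)NO)cc2)c1` gives 66%. Compound 3 `O=C(NO)c1ccc(NCc2nc(-c3ccccc3Cl)nn2-c2ccccc2)cc1` gives 75%, the top number of the three; compound 2 sits within the usual scatter of it, while compound 1 lies below it by a number 12.8 percentage points higher from compound 1 to compound 3 (beyond the scatter), a modest step beyond the scatter.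

Compound 4 `O=C(NO)c1ccc(NCc2nc(-c3ccc(Cl)cc3)nn2-c2ccccc2)cc1` differs from compound 3 in one place: 4-chlorophenyl in place of 2-chlorophenyl on an aromatic carbon.

Among the compounds with values here, only one measured step touches the same aromatic carbon, the one from compound 1 to compound 3, where 2-chlorophenyl in place of 4-methylphenyl brought a number 12.8 percentage points higher from compound 1 to compound 3 (beyond the scatter). Within the data shown here, no measured pair shows the chlorine moved from the 2-position to the 4-position of that phenyl, so the direction of the present change is not covered. Compound 1, which carries a 4-substituted phenyl at this carbon, has the lowest number shown, but that compares a methyl with a chlorine and is not the step in hand.

Among the measured compounds shown here, with no step to lean on, compound 4 is expected to stay within the scatter of compound 3, an estimated step of a number 7 percentage points lower from compound 3 to compound 4 (within the scatter). Compound 4 is estimated at 68% in this assay, with a range from 55% to 80%.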

Compound 4, a percentage reported as inhibition, at one concentration (the size of the read-out at that concentration, not a potency): 67.2%
Compound 4: middle estimate off by 0.8 percentage points, on the high side; the range from low to high includes it.
By their numbers in this assay, from the lowest: compounds 1, 2, 4 and 3 (each within the scatter of the next, the first and the last beyond it).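

In this assay, within the data shown here, the step of 4-chlorophenyl in place of 2-chlorophenyl on this aromatic carbon gives a number 7.8 percentage points lower from compound 3 to compound 4 (within the scatter) and so, for the first time, shows a change in where the chlorine sits on this phenyl, one that the read-out does not separate from the scatter. Chloro in place of methyl, with the phenyl otherwise the same, gives a number 5 percentage points higher from compound 1 to compound 4 (within the scatter) and is not separated either, which leaves a number 12.8 percentage points higher from compound 1 to compound 3 (beyond the scatter) as the only step of the three at this position that clears the scatter, and that step belongs to the 2-chlorophenyl group alone. Nothing at hand offers a reason for any of these steps.

Going by these compounds, whether an amine, a carboxylic acid or a methoxy group on this phenyl, in place of the chlorine, would hold the number in this assay stays open. Also open, on these data alone, is whether the two chlorophenyl compounds would still sit this close in a full concentration series, as a reading at a single concentration is not a potency.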